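A Vinyl for a Diol on a Lipophilic Aminoglycoside Mimic

This account rests on a few compounds, and the source may have more. Where it says the series, first, only, none or still open, it means among the compounds named here.

Compound 1 `CCCCCCCCCO[C@@H]1[C@@H](N)[C@@H](OCC(O)CO)O[C@H](CN)[C@H]1OCCCCCCCCC` was tested in a toxicity assay on the whole organism (J774 cells) for cytotoxicity, with Mus musculus as the target, read by MTT assay, with a stated time of 24 h, tested at 30 uM (on this read-out lower numbers stand for a stronger effect and higher numbers for a weaker effect at the one concentration tested), and there compound 1 gives 8.8%. Compound 2 `NC[C@H]1O[C@H](O[C@H]2[C@H](OCCCc3ccc4ccccc4c3)[C@@H](O)[C@H](N)C[C@@H]2N)[C@H](N)[C@@H](OCCCc2ccc3ccccc3c2)[C@@H]1O` gives 89.5% in this assay, a number that sits beyond the scatter above compound 1, so compound 1 stands lowest of the two on this read-out. Compound 3 `C=CCO[C@H]1O[C@H](CN)[C@@H](OCCCCCCCCC)[C@H](OCCCCCCCCC)[C@H]1N` has not yet been measured. It differs from compound 1 by vinyl in place of 1,2-dihydroxyethyl on a saturated chain carbon bound to an oxygen on a saturated carbon. Among the compounds with values here, no measured pair shows this change, so the step of a number 0.2 percentage points higher from compound 1 to compound 3 (within the scatter) is an expectation only, and the account expects nothing beyond the scatter in either direction. For compound 3 the expected value is 9%, within a range from 2% to 28%.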

Compound 3, a percentage reported as activity, at one concentration (the size of the read-out at that concentration, not a potency): 6.6%
For compound 3 the middle estimate is 2.4 percentage points above the measured one; the measured number falls inside the stated range.
By their numbers in this assay, from the lowest: compounds 3 and 1 (each within the scatter of the next); then compound 2.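

In this assay, vinyl in place of 1,2-dihydroxyethyl on a saturated chain carbon bound to an oxygen on a saturated carbon gives a number 2.2 percentage points lower from compound 1 to compound 3 (within the scatter). At this position, the hydrogen-bond donors and acceptors of the diol can therefore go while the two compounds stay within the scatter of each other. (Nothing at hand speaks to the reason for this result)

As far as these compounds go, whether an amine or a carboxylic acid at the end of this chain, or a propyl in place of the allyl, would also stay within the scatter of compound 1 remains open. This single pair also leaves open whether the same swap would read alike on another core.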